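Replacing naphthalen-1-yl with 4-bromophenyl in compound 3

The source may hold more compounds than are shown below. What is called first, only, known or untested is meant among the compounds shown, and "the series" means these compounds.

Compound 1 (`COc1ccccc1OS(=O)(=O)C1CC2OC1C(c1ccc(NC(=O)CCCCCCC(=O)NO)cc1)=C2c1ccc(O)cc1`), compound 2 (`O=C(CCCCCCC(=O)Nc1ccc(C2=C(c3ccc(O)cc3)C3CC(S(=O)(=O)Oc4ccccc4)C2O3)cc1)NO`) and compound 3 (`O=C(CCCCCCC(=O)Nc1ccc(C2=C(c3ccc(O)cc3)C3CC(S(=O)(=O)Oc4cccc5ccccc45)C2O3)cc1)NO`) share one core and differ in the aromatic group on an oxygen whose other neighbour is the sulfonyl sulfur. In a functional assay on MCF7 cells (Homo sapiens) for inhibition, read by MTT assay, with a stated time of 72 h (on this read-out lower numbers stand for stronger inhibition and higher numbers for weaker inhibition), compound 1 gives 25800 nM while compound 2 gives 30100 nM and compound 3 gives 13400 nM as its reading.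

Compound 3 stands clear of compound 2 alone, by a modest step (a 2.2-fold lower number from compound 2 to compound 3 (0.35 log units; beyond the scatter)). It is not separated from compound 1, as the step between them stays within the scatter (a 1.9-fold lower number from compound 1 to compound 3 (0.28 log units; within the scatter)).

Compound 4 (`O=C(CCCCCCC(=O)Nc1ccc(C2=C(c3ccc(O)cc3)C3CC(S(=O)(=O)Oc4ccc(Br)cc4)C2O3)cc1)NO`) carries 4-bromophenyl in place of naphthalen-1-yl on that oxygen (4-bromophenyl in place of naphthalen-1-yl on an oxygen). Like compound 2, it has a single ring in this group, so part of the modest step from compound 2 may be lost. Among the measured compounds shown here, the one change on that ring measured so far, in compound 2 against compound 1, stayed within the scatter (a 1.2-fold higher number from compound 1 to compound 2 (0.07 log units; within the scatter)). For the measured compounds named here, no measured compound carries bromine, so its contribution is unknown.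

The expected change is small and no step beyond the scatter is expected in this assay (estimated as a 1.5-fold higher number from compound 3 to compound 4 (0.17 log units; within the scatter)). For compound 4 the estimated value is 20000 nM (expected range 9000 nM to 42000 nM).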

Compound 4, half-maximal inhibitory concentration: 17100 nM
Estimate against measurement, compound 4: 1.2-fold (0.07 log units) above; the measured number falls inside the stated range.
By their numbers in this assay, from the lowest: compounds 3, 4, 1 and 2 (each within the scatter of the next, the first and the last beyond it).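

In this assay, the two-ring naphthalen-1-yl on the oxygen attached to the sulfonyl sulfur can give way to the single-ring 4-bromophenyl, which has fewer heavy atoms, without a step that stands out: a 1.3-fold higher number from compound 3 to compound 4 (0.11 log units; within the scatter). The earlier compounds shown here left a gap beyond the scatter between the plain phenyl of compound 2 and the naphthalen-1-yl of compound 3, and compound 4 is separated from neither, since adding bromo to that phenyl gives a 1.8-fold lower number from compound 2 to compound 4 (0.25 log units; within the scatter), while the 2-methoxyphenyl comparison gives a 1.5-fold lower number from compound 1 to compound 4 (0.18 log units; within the scatter). So a second aromatic ring is not required for a reading level with that of compound 3, although nothing available explains this result.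

On these data alone, whether an amine or a carboxylic acid on the phenyl ring in place of bromo, or a saturated cyclohexyl in place of the aromatic group on that oxygen, would give a step beyond the scatter remains open. With bromo shown at only one place on the ring, the compounds also leave open whether 3-bromophenyl or 2-bromophenyl would read the same as 4-bromophenyl.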